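Swapping the pyridine amide for an amino-chloropyridine

A few compounds are considered here, and "the series" means these few. Any claim that something is new, unique, unknown or untested is made for them only; others in the source may bear on it.

Measured compounds:
compound 1, `CC(O)C(=O)Nc1cc(Oc2ccc(Nc3nccc4[nH]cc(-c5ccc(F)cc5)c(=O)c34)cc2F)ccn1`, 47.8%
compound 2, `CC(C)C(=O)Nc1cc(Oc2ccc(Nc3nccc4[nH]cc(-c5ccc(F)cc5)c(=O)c34)cc2F)ccn1`, 83.4%

For the measured compounds named here, in a functional assay on HT-29 cells (Homo sapiens) for antiproliferative activity, read by MTT assay, with a stated time of 72 h, tested at 10 uM (on this read-out lower numbers stand for less inhibition and higher numbers for more inhibition at the one concentration tested (going by the name of the read-out)), compound 2 gives 83.4%, the highest of the two numbers; the only other measured compound, compound 1, lies at 47.8%, and the step of a number 35.6 percentage points higher from compound 1 to compound 2 (beyond the scatter) is beyond the scatter. Compound 3, `Nc1nccc(Oc2ccc(Nc3nccc4[nH]cc(-c5ccc(F)cc5)c(=O)c34)cc2F)c1Cl`, has not been measured. It differs from compound 2 by 2-amino-3-chloropyridin-4-yl in place of 2-((isopropylcarbonyl)amino)pyridin-4-yl on an oxygen on an aromatic ring. Going by the values given here, no measured step touches this exchange: the single step from compound 1 to compound 2 changed only the chain on the amide, whereas here the whole amide-bearing ring is replaced. That step does show that this assay responds strongly to changes in this region, so a step of comparable size in either direction would not surprise. Compound 3 is therefore expected to give 60%, with a range from 25% to 90%. This estimate means an expected step of a number 23.4 percentage points lower from compound 2 to compound 3 (beyond the scatter), a downward guess of low confidence.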

Compound 3, a percentage reported as inhibition, at one concentration (the size of the read-out at that concentration, not a potency): 56.2%
Beside the measured number, compound 3's estimate is 3.8 percentage points above it, within the range that was stated.
By their numbers in this assay, from the lowest: compounds 1 and 3 (each within the scatter of the next); then compound 2.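

In this assay, exchanging the whole amide-bearing ring gives a number 27.2 percentage points lower from compound 2 to compound 3 (beyond the scatter), so 2-amino-3-chloropyridin-4-yl on this oxygen does not keep the level reached with 2-((isopropylcarbonyl)amino)pyridin-4-yl. Set against the amide chain that carries the hydroxy group, the same exchange gives a number 8.4 percentage points higher from compound 1 to compound 3 (within the scatter), which shows that a pyridine without any amide chain can sit at the level of that hydroxy amide. Nothing available here explains either result.

Going by these compounds, the amide chain, the amine and the chlorine all change together in this exchange, so their separate shares in the step stay open; a plain 2-aminopyridin-4-yl group without chlorine would begin to separate them. Also open, on these data alone, is how a longer chain, such as a butanoyl amide, or a cyclopropylcarbonyl amide would compare with the isopropylcarbonyl group.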